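This account rests on a few compounds, and the source may have more. Where it says the series, first, only, none or still open, it means among the compounds named here.

In a functional assay on MCF7 cells (Homo sapiens) for inhibition, read by MTT assay (on this read-out lower numbers stand for stronger inhibition of growth and higher numbers for weaker inhibition of growth), compound 1 (`COc1cc2oc(-c3cccc(NC(=O)c4ccccc4)c3)cc(=O)c2c(OC)c1OC`) gives 12100 nM, compound 2 (`COc1ccc(C(=O)Nc2cccc(-c3cc(=O)c4c(OC)c(OC)c(OC)cc4o3)c2)cc1`) gives 6870 nM, and compound 3 (`COc1cccc(C(=O)Nc2cccc(-c3cc(=O)c4c(OC)c(OC)c(OC)cc4o3)c2)c1`) gives 7670 nM. Compound 3 holds the middle of these three numbers, but it cannot be told apart from the other two: the data show a 1.1-fold higher number from compound 2 to compound 3 (0.05 log units; within the scatter) and a 1.6-fold lower number from compound 1 to compound 3 (0.20 log units; within the scatter).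

Compound 4 (`COc1cccc(C(=O)Nc2cccc(-c3cc(=O)c4c(O)c(OC)c(OC)cc4o3)c2)c1`) departs from compound 3 at a single place: hydrogen in place of methyl on an oxygen on an aromatic ring. This is hydrogen in place of methyl on an oxygen on an aromatic ring, or methoxy to hydroxy.

For the measured compounds named here, no measured step touches that place, so the evidence is only indirect. The closest steps also involve a methoxy group, but as methoxy in place of hydrogen on an aromatic carbon elsewhere in the structure. They give a 1.8-fold lower number from compound 1 to compound 2 (0.25 log units; within the scatter) and a 1.6-fold lower number from compound 1 to compound 3 (0.20 log units; within the scatter). Neither shows how the number responds to losing a methyl from an oxygen, and the data offer no firm direction for this change.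

The expectation therefore stays near compound 3 at 7670 nM, with no step beyond the scatter foreseen. The estimated change is a 1.2-fold lower number from compound 3 to compound 4 (0.07 log units; within the scatter). For compound 4 the expected value is 6500 nM, with an estimated range from 2500 nM to 17000 nM.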

Compound 4, concentration for 50% growth inhibition: 35600 nM
Beside the measured number, compound 4's estimate is 5.5-fold (0.74 log units) below it; measured number above the stated range.
By their numbers in this assay, from the lowest: compounds 2, 3 and 1 (each within the scatter of the next); then compound 4.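

For the compounds shown here, putting hydrogen in place of methyl on an oxygen on an aromatic ring, the change from methoxy to hydroxy, is the first single change here to move the number in this assay beyond the scatter, with a 4.6-fold higher number from compound 3 to compound 4 (0.67 log units; beyond the scatter). Going by these compounds alone, the step is modest, but it points towards weaker inhibition of growth, whereas the earlier steps, which add or shift a methoxy group elsewhere in the structure, all stay within the scatter. This place on the shared core therefore responds to a change that small, and in this series the methyl on that oxygen goes with stronger inhibition of growth than the free hydroxy does. Nothing measured here accounts for the shift.

The compounds shown leave open whether the same change has a similar effect with the unsubstituted benzamide of compound 1 or the 4-methoxyphenyl group of compound 2. They also leave open how this place would respond to a longer chain on the oxygen, such as ethoxy, or to an amine in place of the oxygen group, and so whether the methyl itself matters or any group other than hydroxy would serve.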